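This account rests on a few compounds, and the source may have more. Where it says the series, first, only, none or still open, it means among the compounds named here.

Compound 1 `Cc1cccc(NC(=O)C(Cl)Cl)c1` in a functional assay on A549 cells (Homo sapiens) for antiproliferative activity, read by MTT assay, with a stated time of 72 h (on this read-out lower numbers stand for stronger inhibition and higher numbers for weaker inhibition), gives 41100 nM.
Compound 2 `O=C(Nc1cccc(Cl)c1)C(Cl)Cl` in this assay gives 14800 nM.
Compound 3 `O=C(Nc1cccc(C(F)(F)F)c1)C(Cl)Cl` in this assay gives 12200 nM.

Compound 3 has the lowest number of the three. Its gap to compound 2 is within the scatter, a 1.2-fold lower number from compound 2 to compound 3 (0.08 log units; within the scatter), while compound 1 lies further off, a 3.4-fold lower number from compound 1 to compound 3 (0.53 log units; beyond the scatter). Compound 4 `O=C(Nc1cccc(OC(F)(F)F)c1)C(Cl)Cl` differs from compound 3 by one change, trifluoromethoxy in place of trifluoromethyl on an aromatic carbon of a six-membered aromatic ring of carbon only. Among the measured compounds shown here, no measured step exchanges these two groups directly. The steps that touch this carbon are a 2.8-fold lower number from compound 1 to compound 2 (0.44 log units; beyond the scatter), a 3.4-fold lower number from compound 1 to compound 3 (0.53 log units; beyond the scatter) and a 1.2-fold lower number from compound 2 to compound 3 (0.08 log units; within the scatter); the last shows that swapping chloro for trifluoromethyl there gave no difference beyond the scatter. On that basis the expected step of a 1.1-fold higher number from compound 3 to compound 4 (0.06 log units; within the scatter) is small, with no direction beyond the scatter. Compound 4 is therefore expected to give about 14000 nM in this assay, with a range from 5000 nM to 40000 nM.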

Compound 4, half-maximal inhibitory concentration: 15100 nM
Estimate against measurement, compound 4: 1.1-fold (0.03 log units) below; the range from low to high includes it.
By their numbers in this assay, from the lowest: compounds 3, 2 and 4 (each within the scatter of the next); then compound 1.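

Trifluoromethoxy adds an oxygen to trifluoromethyl, yet at this aromatic carbon the exchange gives no difference beyond the scatter (a 1.2-fold higher number from compound 3 to compound 4 (0.09 log units; within the scatter)), and the same holds against chloro (a 1.0-fold higher number from compound 2 to compound 4 (0.01 log units; within the scatter)). Compound 4 therefore joins compound 2 and compound 3 in a set that this read-out cannot separate, while all three remain apart from the methyl compound (a 2.7-fold lower number from compound 1 to compound 4 (0.43 log units; beyond the scatter)). Nothing available explains why these three groups give such similar numbers or why methyl differs.

The compounds shown leave open whether a different kind of group on this carbon, such as an amine, a carboxylic acid or a longer chain, would shift the number further in either direction. They also leave open whether changes elsewhere in the shared core would matter more.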